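This account rests on a few compounds, and the source may have more. Where it says the series, first, only, none or still open, it means among the compounds named here.

Three compounds of a shared core with a pyrrolidine-linked anilide arm have been measured for plasma stability. Compound 1 `CCOC(=O)C1=C(S[C@@H]2CN[C@H](C(=O)Nc3cccc(C(=O)OCC)c3)C2)[C@H](C)[C@@H]2[C@@H]([C@@H](C)OC(C)=O)C(=O)N12` and compound 2 `CCOC(=O)C1=C(S[C@@H]2CN[C@H](C(=O)Nc3cccc(C(=O)OCC)c3)C2)[C@H](C)[C@@H]2[C@@H]([C@@H](C)OC(=O)CC)C(=O)N12` differ in one place: compound 1 carries hydrogen in place of methyl on a saturated chain carbon bound to a carbonyl carbon relative to compound 2. In an ADME assay on a cell-free system (plasma, Homo sapiens) for metabolic stability, read by LC-MS, with a stated time of 60 min, at 37 degrees C, tested at 50 uM (on this read-out lower numbers stand for a less stable compound and higher numbers for a more stable compound), compound 1 gives 37%, while compound 2 gives 22%, so the step of a number 15 percentage points higher from compound 2 to compound 1 (beyond the scatter) is a rise. Compound 3 `C[C@@H](O)[C@H]1C(=O)N2C(C(=O)O)=C(S[C@@H]3CN[C@H](C(=O)Nc4cccc(C(=O)OCOC(=O)C(C)(C)C)c4)C3)[C@H](C)[C@H]12` belongs to a different core; how it differs from compound 2 is not broken down here. In this assay compound 3 gives 53%, the highest of the three numbers, with compound 1 nearest and compound 2 furthest.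

Compound 4 `CC(C)C(=O)OCOC(=O)c1cccc(NC(=O)[C@@H]2C[C@H](SC3=C(C(=O)O)N4C(=O)[C@H]([C@@H](C)O)[C@H]4[C@H]3C)CN2)c1` is not yet measured. It differs from compound 3 by hydrogen in place of methyl on a saturated chain carbon bound to a carbonyl carbon and two saturated chain carbons. Among the compounds with values here, this is the same kind of change as the one from compound 2 to compound 1, but not the same: in compound 4 the carbon that loses the methyl is bound to a carbonyl carbon and two saturated chain carbons, whereas in compound 1 it is bound to a carbonyl carbon only. Within the data shown here, the only comparable step is the rise a number 15 percentage points higher from compound 2 to compound 1 (beyond the scatter), yet the surroundings of the place differ, so the author expects a smaller shift for compound 4, estimated as a number 3 percentage points lower from compound 3 to compound 4 (within the scatter) in this assay. Compound 4 is therefore expected to give about 50% in this assay, most likely between 30% and 70%.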

Compound 4, percent of the compound remaining: 26%
Beside the measured number, compound 4's estimate is 24 percentage points above it; measured number outside the range, below it.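

The exchange of tert-butyl for isopropyl gives a number 27 percentage points lower from compound 3 to compound 4 (beyond the scatter) in this assay. Hydrogen in place of methyl therefore moved the percent remaining in opposite directions in the two pairs, and the direction of the earlier step did not carry over from one core to the other: the same change on two cores in this assay, a number 15 percentage points higher (beyond the scatter) from compound 2 to compound 1 and a number 27 percentage points lower (beyond the scatter) from compound 3 to compound 4, 42 percentage points apart, beyond the scatter of two such steps This shows that, among these compounds, the result of this kind of change on one core cannot simply be transferred to the other, but it does not show whether the core or the place of the change accounts for the gap, as the carbon that loses the methyl is bound to a carbonyl carbon only in compound 1 and to a carbonyl carbon and two saturated chain carbons in compound 4, and each core offers only one such pair.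

The compounds shown leave open how the same exchange of tert-butyl for isopropyl would read on the core of compound 1, and how the acetyl-to-propionyl difference would read on the core of compound 3. They also leave open where a cyclopropyl group or a longer chain such as n-butyl would fall in this assay's series of numbers.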